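Methoxy for methyl on a second coumarin-like core

The source may report more compounds than this note shows. Statements on the series, on what has been measured and on what is new or still open speak of the compounds shown alone.

Measured compounds:
compound 1 `Cc1ccc2cc(-c3ccc(Br)nn3)c(=O)oc2c1`, 750 nM
compound 2 `COc1ccc2cc(-c3ccc(Br)nn3)c(=O)oc2c1`, 3050 nM
compound 3 `Cc1ccc2oc(=O)c(-c3ccc(Cl)nn3)cc2c1`, 13500 nM

In an assay on cells for inhibition of Amine oxidase [flavin-containing] B (Homo sapiens), read by fluorescence and Amplex Red, with a stated time of 15 min (on this read-out higher numbers stand for weaker inhibition and lower numbers for stronger inhibition), compound 1 gives 750 nM, while compound 3 gives 13500 nM, the highest number of the three. The difference between the cores of compound 1 and compound 3 is not broken down here. The step of a 4.1-fold higher number from compound 1 to compound 2 (0.61 log units; beyond the scatter) came from one change, (methoxy in place of methyl on an aromatic carbon).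

Compound 4 `COc1ccc2oc(=O)c(-c3ccc(Cl)nn3)cc2c1` is not yet measured. It arises from compound 3 by the same change, (methoxy in place of methyl on an aromatic carbon), at the same place. It is expected to move in the same direction, about as far: a step of a 3.7-fold higher number from compound 3 to compound 4 (0.57 log units; beyond the scatter), resting only on the step from compound 1 to compound 2. Compound 4 is therefore estimated at 50000 nM, likely between 15000 nM and 160000 nM, if the measurement returns a number at all.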

Compound 4, half-maximal inhibitory concentration: 8800 nM
Compound 4: middle estimate off by 5.7-fold (0.75 log units), on the high side; the whole stated range lies above it.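

On the second core, methoxy in place of methyl gives a 1.5-fold lower number from compound 3 to compound 4 (0.19 log units; within the scatter) in this assay, so the change leaves no clear mark here. A step measured on one core therefore does not carry over to the other in this series: the same change on two cores in this assay, a 4.1-fold higher number (0.61 log units; beyond the scatter) from compound 1 to compound 2 and a 1.5-fold lower number (0.19 log units; within the scatter) from compound 3 to compound 4, 6.2-fold (0.80 log units) apart, beyond the scatter of two such steps This shows that the two steps differ, but with one pair on each core it does not show why, or how the change would behave on any further core.

Compound 1 and compound 2 carry bromine while compound 3 and compound 4 carry chlorine, and the compounds shown leave open whether the halogen or the rest of the core separates the two steps. They also leave open how an amine or a longer chain such as ethoxy would fare in the same place.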